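The source may report more compounds than this note shows. Statements on the series, on what has been measured and on what is new or still open speak of the compounds shown alone.

Measured so far, in an ADME assay on liver with Liver microsome (Homo sapiens) as the target, read by LC-MS, using microsomes, with a stated time of 30 min, tested at 1 uM; a lower number here means that the liver removes a smaller share, a higher number that the liver removes a larger share of the compound in one pass:
compound 1, `Cc1cc(-c2ccncc2NC(=O)c2nc(-c3ccccc3F)ccc2N)cc(N)n1`: 0.95
compound 2, `Cc1cc(-c2ccncc2NC(=O)c2nc(-c3c(F)cccc3F)ccc2N)cc(N)n1`: 0.96

Compound 2 holds the higher of the two numbers in this assay, with compound 1 nearest; the gap between them is a number 0.010 higher from compound 1 to compound 2 (within the scatter) and so within the scatter. Both values lie close to the upper end of the scale.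

Compound 3 is `Cc1nc(N)cc(-c2ccncc2NC(=O)c2nc(-c3c(F)cccc3F)ccc2N)n1`. It differs from compound 2 by 6-amino-2-methylpyrimidin-4-yl in place of 2-amino-6-methylpyridin-4-yl on an aromatic carbon.

Among the compounds with values here, the single measured step, fluoro in place of hydrogen on an aromatic carbon, is a change of another kind and does not bear on this exchange of one ring for another. No step of the present kind has been measured in the series, so nothing shown speaks for a move in either direction. Given that compound 2 already stands near the ceiling of the scale, the expectation is that compound 3 stays within the scatter of compound 2, and the step expected is a number 0.020 lower from compound 2 to compound 3 (within the scatter). Compound 3 is therefore estimated at 0.94, with a range from 0.85 to 0.99.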

Compound 3, hepatic extraction ratio: 0.82
Compound 3: middle estimate off by 0.12, on the high side, and the stated range ends above it.
By their numbers in this assay, from the lowest: compound 3; then compounds 1 and 2 (each within the scatter of the next).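

In this assay, within the data shown here, this position on an aromatic carbon opposite the ring nitrogen is sensitive to the ring exchange: 6-amino-2-methylpyrimidin-4-yl in place of 2-amino-6-methylpyridin-4-yl gives a number 0.14 lower from compound 2 to compound 3 (beyond the scatter), the first step beyond the scatter. The two groups have the same 8 heavy atoms and differ in composition, 5 carbon and 3 nitrogen against 6 carbon and 2 nitrogen, so a change of this small extent is enough to bring the number down from near the top of the scale. Nothing at hand bears on why the number falls.

From the compounds shown here alone, it remains open whether the same exchange gives a step of this size on the core of compound 1. Also open, going by these compounds, is how the number responds to a morpholine or a carboxylic acid at this aromatic carbon.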